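Adding a Phenethyloxy Group to the Pyridinyl Analogue

The source may hold more compounds than are shown below. What is called first, only, known or untested is meant among the compounds shown, and "the series" means these compounds.

Compound 1 `CCCn1ccc2cc(N3CCNCC3)cc(Cl)c2c1=O`: 47%
Compound 2 `CCCn1ccc2cc(-c3cccnc3)cc(Cl)c2c1=O`: 83%

In a functional assay on CHO cells for agonist activity at metabotropic glutamate receptor 2 (Homo sapiens), read by GTPgammaS binding (a higher number here means a larger maximal response, a lower number a smaller maximal response), compound 2 gives the higher of the two numbers, and the step of a number 36 percentage points higher from compound 1 to compound 2 (beyond the scatter) lies beyond the scatter. Compound 3 `CCCn1ccc2cc(-c3ccc(OCCc4ccccc4)nc3)cc(Cl)c2c1=O` keeps the pyridin-3-yl of compound 2 and differs only by phenethyloxy in place of hydrogen on an aromatic carbon. For the measured compounds named here, the single measured step swaps one whole group for another; no step adds a group to the pyridin-3-yl, so it does not bear directly on this change. With nothing pointing either way, compound 3 is expected to give about 85% (range 60% to 110%), a step of a number 2 percentage points higher from compound 2 to compound 3 (within the scatter) that is estimated to stay within the scatter.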

Compound 3, largest response reached (Emax), in percent of the reference or control that the assay uses: 103%
Estimate against measurement, compound 3: 18 percentage points below; low and high end bracket the measured number.
By their numbers in this assay, from the lowest: compound 1; then compound 2; then compound 3.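

The pyridin-3-yl ring of compound 2 still has room for growth: on the aromatic carbon next to the ring nitrogen and para to a large group, phenethyloxy in place of hydrogen gives a number 20 percentage points higher from compound 2 to compound 3 (beyond the scatter) in this assay. This is the first step shown that adds a group to that ring rather than swapping one whole group for another. No measurement shown gives a reason for this rise.

Which part of phenethyloxy matters remains open, whether the phenyl ring, the oxygen or the two-carbon chain. A methoxy group, a benzyloxy group or an amine at the same place could begin to separate these parts.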